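The source may report more compounds than this note shows. Statements on the series, on what has been measured and on what is new or still open speak of the compounds shown alone.

Working notes on the series, values in an ADME assay on MDCK cells (Canis lupus familiaris) for permeability; a lower number here means that the compound crosses the layer more slowly, a higher number that the compound crosses the layer faster

- compound 1 `Cn1cc(-c2cc(C(N)=O)ccc2Oc2ccccc2)c2cc[nH]c2c1=O` gives 14 10^-6 cm/s
- compound 2 `Cn1cc(-c2cc(S(N)(=O)=O)ccc2Oc2ccccc2)c2cc[nH]c2c1=O` gives 22 10^-6 cm/s
- compound 3 `Cn1cc(-c2cc(NS(C)(=O)=O)ccc2Oc2ccccc2C(F)(F)F)c2cc[nH]c2c1=O` gives 7.8 10^-6 cm/s

Compound 3 at 7.8 10^-6 cm/s lies within the scatter of compound 1 at 14 10^-6 cm/s. Compound 2 at 22 10^-6 cm/s reads higher than compound 3, and that gap lies beyond the scatter.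

The next compound to be read is compound 4 `Cn1cc(-c2cc(NS(C)(=O)=O)ccc2OC2CCC(F)(F)CC2)c2cc[nH]c2c1=O`, which carries 4,4-difluorocyclohexyl in place of 2-(trifluoromethyl)phenyl on an oxygen on an aromatic ring. The counted difference is 4,4-difluorocyclohexyl in place of 2-(trifluoromethyl)phenyl on an oxygen on an aromatic ring.

Within the data shown here, only one measured step links two compounds that differ in one place. It is a 1.6-fold higher number from compound 1 to compound 2 (0.20 log units; within the scatter), with sulfamoyl in place of carbamoyl on an aromatic carbon, and it lies within the scatter. Among the measured compounds shown here, that step does not touch the group on the oxygen, and no measured step changes that group, so it bears on the present change only loosely. For the measured compounds named here, with no direct precedent, no direction can be supported in this assay and no shift beyond the scatter is expected.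

The expected step is a 1.2-fold higher number from compound 3 to compound 4 (0.06 log units; within the scatter).

For compound 4 the estimated value is 9 10^-6 cm/s, with an expected range from 4 10^-6 cm/s to 18 10^-6 cm/s.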

Compound 4, apparent permeability: 12 10^-6 cm/s
For compound 4 the middle estimate is 1.3-fold (0.12 log units) below the measured one, within the range that was stated.
By their numbers in this assay, from the lowest: compounds 3, 4, 1 and 2 (each within the scatter of the next, the first and the last beyond it).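

Among these compounds, on an oxygen on an aromatic ring, 4,4-difluorocyclohexyl in place of 2-(trifluoromethyl)phenyl gives a 1.5-fold higher number from compound 3 to compound 4 (0.19 log units; within the scatter) in this assay, and this is the only measured step that changes the group at this position. The read-out therefore does not separate the two groups, even though a six-membered aromatic ring of carbon only, with 10 heavy atoms in the group, gives way to a six-membered non-aromatic ring of carbon only, with 8 heavy atoms in the group. No accompanying data offer an account of this result.

From the compounds shown here alone, the step is read in a single setting, the rest of compound 3, so whether it carries over to the carbamoyl of compound 1 or the sulfamoyl of compound 2 remains open. Also open, going by these compounds, is how the number would respond to an amine or a carboxylic acid on the ring at this position, or to a longer alkyl chain on the oxygen in place of either ring.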